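The compounds below may be only part of what the source reports. "The series", "measured", "known", "first", "only" and "open" are said of these compounds alone.

In a functional assay on MCF7 cells (Homo sapiens) for inhibition, read by MTT assay, with a stated time of 72 h (a lower number here means a stronger inhibitor, a higher number a weaker inhibitor), compound 1 `COc1cc(OC)c(OC)cc1/C=C/C(=O)c1ccc(Cl)cc1`, bearing chloro, gives 29500 nM, and compound 3 `COc1cc(OC)c(OC)cc1/C=C/C(=O)c1ccc(C)cc1`, bearing methyl, gives 33000 nM; these two values cannot be told apart. Compound 2 `COc1cc(OC)c(OC)cc1/C=C/C(=O)c1ccccc1`, bearing hydrogen, reaches only a limit, > 150000 nM. Compound 4 `COc1cc(OC)c(OC)cc1/C=C/C(=O)c1ccc(F)cc1` is still unmeasured: fluoro in place of methyl on an aromatic carbon. Hydrogen in place of chloro gave an at least 5.0-fold higher number from compound 1 to compound 2 (0.70 log units; beyond the scatter) and methyl in place of hydrogen gave an at least 4.5-fold lower number from compound 2 to compound 3 (0.65 log units; beyond the scatter), both beyond the scatter, while methyl in place of chloro gave a 1.1-fold higher number from compound 1 to compound 3 (0.05 log units; within the scatter), within it. Compound 4 keeps a group other than hydrogen there, as compound 3 does at 33000 nM, so no step beyond the scatter is expected in this assay. The expected step is a 1.2-fold higher number from compound 3 to compound 4 (0.08 log units; within the scatter). For compound 4 the estimated value is 40000 nM, with an expected range from 18000 nM to 110000 nM.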

Compound 4, half-maximal inhibitory concentration: 30000 nM
Estimate against measurement, compound 4: 1.3-fold (0.12 log units) above; low and high end bracket the measured number.
By their numbers in this assay, from the lowest: compounds 1, 4 and 3 (each within the scatter of the next). At a limit, above all of these: compound 2.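

In this assay, fluoro joins methyl and chloro at this position: a 1.1-fold lower number from compound 3 to compound 4 (0.04 log units; within the scatter) and a 1.0-fold higher number from compound 1 to compound 4 (0.01 log units; within the scatter), both within the scatter. Three different groups on this aromatic carbon now give values that cannot be told apart, and fluoro also separates from hydrogen, with an at least 5.0-fold lower number from compound 2 to compound 4 (0.69 log units; beyond the scatter), beyond the scatter. That step starts from a limit, not a number: the limit of > 150000 nM in this assay, at which 1 of the 4 values shown sits.

From the compounds shown here alone, whether an amine, a carboxylic acid or a longer chain at this place would stay level with these three compounds remains open. Going by these compounds, how far compound 2 truly lies from them also remains open.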